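Dimethylamino for Phenoxy: What Compound 3 Might Show

The compounds below may be only part of what the source reports. "The series", "measured", "known", "first", "only" and "open" are said of these compounds alone.

Measured so far:
Compound 1 `COc1cc(C)cc(-c2nn(CC#N)cc2-c2ccc(-c3cccc(C(C)=O)c3)nc2)c1` gives 94% in a functional assay on PC-3 cells (Homo sapiens) for cytotoxicity, read by sulforhodamine B assay, with a stated time of 48 h, tested at 0.001 uM; a higher number here means a weaker effect of the compound at the concentration tested, a lower number a stronger effect.
Compound 2 `Cc1cc(O)cc(-c2nn(CC#N)cc2-c2ccnc(-c3ccc(Oc4ccccc4)cc3)c2)c1` gives 98% in this assay.

Going by the values given here, compound 2 stands highest of the two numbers, yet its only neighbour, compound 1, sits so close that the gap between the two lies within the usual scatter; no ordering of the pair can be read from these values. Both compounds leave the cells almost untouched at the concentration tested.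

Compound 3 `Cc1cc(O)cc(-c2nn(CC#N)cc2-c2ccnc(-c3ccc(N(C)C)cc3)c2)c1` differs from compound 2 in one place: dimethylamino in place of phenoxy on an aromatic carbon. Nothing measured here speaks to this exchange, since no change between two measured compounds has been recorded. With both known values sitting near full activity, the step from compound 2 to compound 3 in this assay is expected to be none beyond the scatter, a number 2 percentage points lower from compound 2 to compound 3 (within the scatter). Compound 3 is therefore estimated at 96%, within a range from 86% to 104%.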

Compound 3, a percentage reported as activity, at one concentration (the size of the read-out at that concentration, not a potency): 105%
Estimate against measurement, compound 3: 9 percentage points below, outside the stated range (above it).
By their numbers in this assay, from the lowest: compounds 1, 2 and 3 (each within the scatter of the next, the first and the last beyond it).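

In this assay, going by these compounds alone, dimethylamino in place of phenoxy on this aromatic carbon gives a number 7 percentage points higher from compound 2 to compound 3 (within the scatter), the first step between two measured compounds that differ in one place. At this position, para to a large group, the exchange removes a six-membered aromatic ring of carbon only, yet the read-out at this single concentration stays within the scatter. Nothing available here accounts for this result.

The compounds shown leave open whether a carboxylic acid, a morpholine ring or a longer chain on the same aromatic carbon would shift the read-out beyond the scatter. They also leave open whether phenoxy and dimethylamino would still read alike at concentrations where the cells are clearly affected.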